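From One Chloro to Two on Compound 3

The source may hold more compounds than are shown below. What is called first, only, known or untested is meant among the compounds shown, and "the series" means these compounds.

Compound 1 `COc1cc(/C=C2\CN(C)C/C(=C\c3ccc(Cl)cc3)C2=O)cc(OC)c1` gives 13300 nM
Compound 2 `COc1cc(/C=C2\CN(C)C/C(=C\c3cc(OC)c(OC)c(OC)c3)C2=O)cc(OC)c1` gives 3470 nM
Compound 3 `COc1cc(/C=C2\CN(C)C/C(=C\c3ccc(Cl)cc3)C2=O)cc(OC)c1OC` gives > 20000 nM (a limit, not a number)

In a functional assay on K562 cells (Homo sapiens) for cytotoxicity, read by MTT assay, with a stated time of 24 h (on this read-out lower numbers stand for stronger inhibition and higher numbers for weaker inhibition), compound 3 gives only a limit (the limit of > 20000 nM in this assay, at which 1 of the 3 values shown sits). Compound 4 `COc1cc(/C=C2\CN(C)C/C(=C\c3ccc(Cl)c(Cl)c3)C2=O)cc(OC)c1OC` differs from it by one change chloro in place of hydrogen on an aromatic carbon that turns 4-chlorophenyl into 3,4-dichlorophenyl.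

Among the measured compounds shown here, no measured step makes this change. The nearest evidence comes from other swaps. A methoxy in place of hydrogen gave an at least 1.5-fold higher number from compound 1 to compound 3 (0.17 log units; that floor lies within the scatter) and 4-chlorophenyl in place of 3,5-dimethoxyphenyl gave an at least 5.7-fold higher number from compound 2 to compound 3 (0.76 log units; beyond the scatter) as its result. Neither shows what a second chloro does, so only a modest move toward lower numbers is expected, and compound 4 may also stay at the limit. The expected step is an at least 1.4-fold lower number from compound 3 to compound 4 (0.15 log units; that floor lies within the scatter) in size. For compound 4 the estimated value in this assay is 14000 nM (range 5000 nM to 35000 nM).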

Compound 4, half-maximal inhibitory concentration: 16200 nM
For compound 4 the middle estimate is 1.2-fold (0.06 log units) below the measured one; the measured number falls inside the stated range.
By their numbers in this assay, from the lowest: compound 2; then compounds 1 and 4 (each within the scatter of the next). At a limit, above all of these: compound 3.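

In this assay, chloro in place of hydrogen gives an at least 1.2-fold lower number from compound 3 to compound 4 (0.09 log units; that floor lies within the scatter), so a second chloro at this position is not shown to change the result beyond the scatter. Going by these compounds, compound 3 has a limit rather than a number, so the true size of this step stays unknown: the limit of > 20000 nM in this assay, at which 1 of the 4 values shown sits. Even with the second chloro, 3,4-dichlorophenyl in place of 3,5-dimethoxyphenyl gives a 4.7-fold higher number from compound 2 to compound 4 (0.67 log units; beyond the scatter), a modest gap beyond the scatter.

On these data alone, what an amine or a carboxylic acid would do at this position remains open.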